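Salicylanilide cytotoxicity: from a pyrrolidine to a branched chain

The source may hold more compounds than are shown below. What is called first, only, known or untested is meant among the compounds shown, and "the series" means these compounds.

Measured compounds:
compound 1, `CCCN(CCC)c1ccc(NC(=O)c2cc(Cl)ccc2O)c(Cl)c1`, 323000 nM
compound 2, `O=C(Nc1ccc(N2CCCC2)cc1Cl)c1cc(Cl)ccc1O`, "not determined" (no result reported)
compound 3, `O=C(Nc1ccc(NCC2CCNCC2)cc1Cl)c1cc(Cl)ccc1O`, "not determined" (no result reported)

The series shares one amide core and differs only in the group on the ring that carries the chloro substituent. In an ADME assay on A549 cells (Homo sapiens) for cytotoxicity, read by LDH release, with a stated time of 15 h (a higher number here means that more compound is tolerated, a lower number that less compound is tolerated), compound 1 gives 323000 nM, a high tolerated concentration. Compound 2 has no single number in this assay, and compound 3 is the one further entry without a number, so compound 2 cannot be placed against any neighbour on the numbers shown.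

Compound 4, `CCCCCCC(C)Nc1ccc(NC(=O)c2cc(Cl)ccc2O)c(Cl)c1`, is not yet measured. It differs from compound 2 as follows: (1-methylheptyl)amino in place of pyrrolidin-1-yl on an aromatic carbon. Among the measured compounds shown here, no step between measured compounds is recorded, so the size of the move from compound 2 to compound 4 in this assay can only be guessed. With compound 1 as the single reference, a tolerated concentration of the same broad order as that of compound 1 is expected, and any shift beyond the scatter, if one occurs, is expected to be towards less compound tolerated rather than more. The estimate for compound 4 in this assay is 150000 nM, expected to fall between 40000 nM and 400000 nM.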

Compound 4, half-maximal cytotoxic concentration: 18600 nM
Compound 4: middle estimate off by 8.1-fold (0.91 log units), on the high side; the whole stated range lies above it.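

In this assay the exchange of dipropylamino for (1-methylheptyl)amino on the aromatic carbon gives a 17-fold lower number from compound 1 to compound 4 (1.24 log units; beyond the scatter) and lies beyond the usual scatter. Among the compounds shown here, this is the first readable step: until now the position had a single number, and nothing showed that the group held there could change how much compound the cells tolerate. The step marks a sensitive position but does not show which feature of the change is responsible, and nothing available accounts for it.

Steps involving compound 2 or compound 3 cannot be read, as neither has a number, so the pyrrolidin-1-yl group and the piperidine-bearing amine of compound 3 remain unplaced against the two measured amines. Still open, from the compounds shown here alone, is whether the lower number follows the branch, the chain length or the nitrogen hydrogen, which an unbranched octylamino chain, a shorter butylamino chain or a tertiary amine carrying the same 1-methylheptyl chain could separate.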